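The source may hold more compounds than are shown below. What is called first, only, known or untested is meant among the compounds shown, and "the series" means these compounds.

Series notes, step from compound 2 to compound 3.

In a functional assay on isolated protein for antagonist activity at C-C chemokine receptor type 9 (Homo sapiens), read by calcium flux, with a stated time of 10 min (on this read-out lower numbers stand for stronger inhibition and higher numbers for weaker inhibition), compound 1 `COc1ccnc(-c2cc(Cl)ccc2NS(=O)(=O)c2ccc(C(C)(C)C)cc2)c1` gives 2500 nM and compound 2 `CC(C)(C)c1ccc(S(=O)(=O)Nc2ccc(Cl)cc2-c2c(O)ccc[n+]2[O-])cc1` gives 491 nM. Among the compounds with values here, the single measured step, a 5.1-fold lower number from compound 1 to compound 2 (0.71 log units; beyond the scatter), is the only one beyond the scatter, so compound 2 holds the lowest number of the two.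

Compound 3 `CC(C)(C)c1ccc(S(=O)(=O)Nc2ccc(Cl)cc2-c2nc(N)ncc2O)cc1` carries a group of 8 heavy atoms (4 carbon, 3 nitrogen, 1 oxygen; one six-membered aromatic ring with 2 hetero atoms) in place of a group of 8 heavy atoms (5 carbon, 1 nitrogen, 2 oxygen; one six-membered aromatic ring with 1 hetero atom), on an aromatic carbon, the site being on an aromatic carbon of the shared core, ortho to a large group and meta to a chloro group. Within the data shown here, no measured step exchanges one six-membered aromatic ring for another at this position in the same way; the step from compound 1 to compound 2 only shows that the group here moves the number by a modest amount. Among the measured compounds shown here, with no closer precedent, the expected change from compound 2 to compound 3 is a 1.6-fold higher number from compound 2 to compound 3 (0.21 log units; within the scatter), which is within the scatter. Compound 3 is therefore estimated at 800 nM in this assay, with a range from 200 nM to 4000 nM.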

Compound 3, half-maximal inhibitory concentration: 4 nM
Estimate against measurement, compound 3: 200-fold (2.30 log units) above; measured number below the stated range.
By their numbers in this assay, from the lowest: compound 3; then compound 2; then compound 1.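

In this assay, within the data shown here, this position, on an aromatic carbon ortho to a large group and meta to a chloro group, tolerates far more than a modest shift: a 5.1-fold lower number from compound 1 to compound 2 (0.71 log units; beyond the scatter) was the only earlier reading, whereas the new group gives a 120-fold lower number from compound 2 to compound 3 (2.09 log units; beyond the scatter) and a 630-fold lower number from compound 1 to compound 3 (2.80 log units; beyond the scatter). The size of the effect therefore depends strongly on which six-membered aromatic ring sits here, and the ring with 2 hetero atoms, 2 hydrogen-bond donors and 4 hydrogen-bond acceptors gives the lowest number of the three compounds. No measurement available here accounts for this gain.

Ring hetero atoms, donors and acceptors all change together in this step, so the contribution of each remains unresolved. A methyl group in place of the amine on the ring of compound 3 would be one open comparison.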